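Thiazole for difluorophenyl on the cyclopropane of compound 3

The source may hold more compounds than are shown below. What is called first, only, known or untested is meant among the compounds shown, and "the series" means these compounds.

For the measured compounds named here, compound 3 `CC[C@H](C)[C@H](N)CN(C(=O)[C@@H]1C[C@H]1c1ccc(F)c(F)c1)c1ccc(-c2ccccc2)cc1` carries the lowest of the two numbers so far in a functional assay for agonist activity at G protein-coupled receptor 88 (Homo sapiens), read by HTRF and cAMP accumulation; a higher number here means that more compound is needed for the effect, a lower number that less compound is needed; in this assay compound 3 gives 720 nM. Its nearest neighbour, compound 2 `CC[C@H](C)[C@H](N)CN(C(=O)[C@@H]1C[C@H]1c1cc(F)ccc1F)c1ccc(-c2ccccc2)cc1`, gives 770 nM in this assay, and the step of a 1.1-fold lower number from compound 2 to compound 3 (0.03 log units; within the scatter) is within the scatter. Compound 1 `CC[C@H](C)[C@H](N)CN(C(=O)[C@@H]1C[C@H]1c1ccc(C#N)cc1)c1ccc(-c2ccccc2)cc1` reaches only a limit of this assay, > 25000 nM (the limit of > 25000 nM in this assay, at which 1 of the 3 values shown sits). The steps of an at least 32-fold lower number from compound 1 to compound 2 (1.51 log units; beyond the scatter) and an at least 34-fold lower number from compound 1 to compound 3 (1.54 log units; beyond the scatter) are large and show that the group on the saturated ring carbon decides the potency in this set.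

Compound 4 `CC[C@H](C)[C@H](N)CN(C(=O)[C@@H]1C[C@H]1c1nc(C)c(C)s1)c1ccc(-c2ccccc2)cc1` has not been measured. The change from compound 3 is 4,5-dimethyl-1,3-thiazol-2-yl in place of 3,4-difluorophenyl on a saturated ring carbon. Going by the values given here, no measured step swaps the six-membered aromatic ring for a five-membered ring with hetero atoms; the measured changes only alter the substituents on that ring. The two difluorophenyl compounds sit together, while the 4-cyanophenyl compound 1 gives only a limit, so the outcome of this change is open. For compound 4 a moderately higher number is expected, a step of a 2.8-fold higher number from compound 3 to compound 4 (0.44 log units; beyond the scatter). The estimate for compound 4 is 2000 nM, within 500 nM to 10000 nM.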

Compound 4, half-maximal effective concentration: 3600 nM
The estimate for compound 4 lay 1.8-fold (0.26 log units) below the measured number; the range from low to high includes it.
By their numbers in this assay, from the lowest: compounds 3 and 2 (each within the scatter of the next); then compound 4. At a limit, above all of these: compound 1.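

In this assay, the 2-(3,4-difluorophenyl)cyclopropyl position also accepts a five-membered aromatic ring with 2 hetero atoms, at a modest cost: a 5.0-fold higher number from compound 3 to compound 4 (0.70 log units; beyond the scatter) and a 4.7-fold higher number from compound 2 to compound 4 (0.67 log units; beyond the scatter). Against the 4-cyanophenyl group the same ring gives an at least 6.9-fold lower number from compound 1 to compound 4 (0.84 log units; beyond the scatter), so 4,5-dimethyl-1,3-thiazol-2-yl ranks between the two difluorophenyl groups and 4-cyanophenyl, and a six-membered aromatic ring is not required for a measurable number. Compound 1 gives a limit, not a number: the limit of > 25000 nM in this assay, at which 1 of the 4 values shown sits.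

The compounds shown do not separate the contribution of the thiazole ring from that of its two methyl groups, which a 1,3-thiazol-2-yl group without methyl groups would address. From the compounds shown here alone, how a pyridin-2-yl group would compare at this position also remains open.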